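Loss of a Protecting Group on Two Related Scaffolds

A few compounds are considered here, and "the series" means these few. Any claim that something is new, unique, unknown or untested is made for them only; others in the source may bear on it.

Compound 1 `CC(C)[C@H](NC(=O)c1cc(Cl)ccc1OCCCCNC(=O)OC(C)(C)C)C(=O)Nc1ccc([N+](=O)[O-])cc1Cl`: > 10000 nM
Compound 2 `CC(C)[C@H](NC(=O)c1cc(Cl)ccc1OCCCCN)C(=O)Nc1ccc([N+](=O)[O-])cc1Cl`: > 10000 nM
Compound 3 `CC(C)[C@H](NC(=O)c1cc(Cl)ccc1OCCNC(=O)OC(C)(C)C)C(=O)Nc1ccc(F)c(F)c1`: > 10000 nM

Of the compounds shown here, three have been tested in a functional assay on MCF7 cells (Homo sapiens) for inhibition, read by MTT assay, with a stated time of 72 h; on this read-out higher numbers stand for weaker inhibition and lower numbers for stronger inhibition. Compound 1 reaches only the limit of the assay, at > 10000 nM. Compound 2, which carries hydrogen in place of tert-butoxycarbonyl on an amine nitrogen, also sits at the limit, > 10000 nM. The step between them is therefore a step that the two limits leave unreadable from compound 1 to compound 2. Compound 3 likewise gives only a limit in this assay, > 10000 nM. The difference between the core of compound 1 and the core of compound 3 is not broken down here.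

Compound 4 `CC(C)[C@H](NC(=O)c1cc(Cl)ccc1OCCN)C(=O)Nc1ccc(F)c(F)c1` has not been measured. It carries hydrogen in place of tert-butoxycarbonyl on an amine nitrogen, the same change that separates compound 1 from compound 2, on the same place. Because (the limit of > 10000 nM in this assay, at which 3 of the 3 values shown sit), there is nothing in the measured set that resolves the effect of this change. Compound 4 is expected to show a step that the limit leaves unreadable from compound 3 to compound 4 from compound 3 in this assay, which rests on the unreadable step from compound 1 to compound 2. Compound 4 is estimated at 15000 nM, in the range 7000 nM to 60000 nM.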

Compound 4, half-maximal inhibitory concentration: > 10000 nM
Compound 4: a limit, no number; the forecaster's own chance of this, stated with the estimate: 85%; the middle value lies beyond the limit too.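

Compound 4 gives > 10000 nM, which is a limit and not a number. No step can be read from compound 3 to compound 4, and the hydrogen in place of tert-butoxycarbonyl remains unsized on both scaffolds: the limit of > 10000 nM in this assay, at which 4 of the 4 values shown sit.

The compounds shown leave open how strongly any of them inhibits in this assay, and whether removing tert-butoxycarbonyl changes that inhibition at all.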